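A few compounds are considered here, and "the series" means these few. Any claim that something is new, unique, unknown or untested is made for them only; others in the source may bear on it.

Measured compounds:
- compound 1 `Cc1c(OC[C@@H](C)COc2ccc(C(=O)O)c(Cl)c2)ccc(C(=O)CC(C)(C)C)c1O`: 50 nM
- compound 2 `COc1ccccc1OC[C@H](C)COc1ccc(C(=O)CC(C)(C)C)c(O)c1C`: "not active" (no number reported)

In an assay for positive allosteric modulation of metabotropic glutamate receptor 2 (Rattus norvegicus) (on this read-out higher numbers stand for an effect only at larger amounts of compound and lower numbers for an effect already at smaller amounts), compound 1 gives 50 nM. Compound 2 carries a 2-methoxyphenoxy group in place of the acid-bearing aryloxy group of compound 1. In this assay, among the compounds with values here, compound 2 gives "not active" (no number reported), so for compound 2 no single number stands, and no counted step between compound 1 and compound 2 can be given; the two results only show that compound 1 has a measured value and compound 2 does not.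

Compound 3 `COc1cccc(OC[C@H](C)COc2ccc(C(=O)CC(C)(C)C)c(O)c2C)c1` is not yet measured. It differs from compound 2 by 3-methoxyphenyl in place of 2-methoxyphenyl on an oxygen on a saturated carbon, the same atoms joined differently. Within the data shown here, with no number for compound 2, no step size in this assay can be counted from it, and compound 1 offers no direct step either. Because compound 2 gives "not active" (no number reported), the expectation for compound 3 is a weak result, with a real chance that this assay again reports no number. Compound 3 is estimated at 3000 nM in this assay, with a range from 400 nM to 20000 nM.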

Compound 3, half-maximal effective concentration: "not active" (no number reported)
For compound 3 the study gives words and no number, and the estimate cannot be compared.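

In this assay compound 2 gives "not active" (no number reported) and compound 3 gives "not active" (no number reported) so no step can be read between them. No measurement shown here offers an explanation for either result. The compounds shown leave open whether any methoxyphenoxy group in place of the acid-bearing aryloxy group of compound 1 can give a measurable value.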